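From a 4-Bromophenyl to a 3-Chlorophenyl Amide

The compounds below may be only part of what the source reports. "The series", "measured", "known", "first", "only" and "open" are said of these compounds alone.

Of the compounds shown here, three have been measured. Compound 1 `O=C(CSC(=S)N[C@H]1CCOC1=O)Nc1ccc(Cl)cc1` was tested in a functional assay on SMMC-7721 cells (Homo sapiens) for cytotoxicity, read by MTT assay, with a stated time of 72 h (a higher number here means a weaker inhibitor, a lower number a stronger inhibitor), and gave only a limit of the assay, > 128000 nM. Compound 2 `O=C(CSC(=S)N[C@H]1CCOC1=O)Nc1ccc(Br)cc1` gives 28300 nM in this assay. Compound 3 `Cc1cccc(NC(=O)CSC(=S)N[C@H]2CCOC2=O)c1C` gives 42200 nM in this assay.

Among the two numbers that are not limits, compound 2 has the lower one, but its distance to compound 3 is within the usual scatter, so the two cannot be ranked. Going by the values given here, the only single-point step available is an at least 4.5-fold lower number from compound 1 to compound 2 (0.65 log units; beyond the scatter); since compound 1 sits at the limit, (the limit of > 128000 nM in this assay, at which 1 of the 3 values shown sits), the true size of that step is only known as a minimum.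

Compound 4 `O=C(CSC(=S)N[C@H]1CCOC1=O)Nc1cccc(Cl)c1` differs from compound 2 by 3-chlorophenyl in place of 4-bromophenyl on an amide-type nitrogen. This change has two parts: the halogen itself and where it sits on the ring. Only the first part has a measured counterpart, and there bromo gave the lower number. Among the compounds with values here, no measured pair shows what shifting the halogen does. Taking the halogen swap at face value, a higher number is expected for compound 4 than for compound 2, with wide uncertainty because of the limit in the limit of > 128000 nM in this assay, at which 1 of the 3 values shown sits; the expected step is a 2.5-fold higher number from compound 2 to compound 4 (0.39 log units; beyond the scatter). Compound 4 is thus estimated at 70000 nM, with a range from 20000 nM to 250000 nM.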

Compound 4, half-maximal inhibitory concentration: > 128000 nM
Compound 4: a limit, no number; the forecaster's own chance of this, stated with the estimate: 30%; middle value at least 1.8-fold (0.26 log units) away from the limit.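

Putting 3-chlorophenyl in place of 4-bromophenyl on the amide-type nitrogen gives an at least 4.5-fold higher number from compound 2 to compound 4 (0.65 log units; beyond the scatter) in this assay, so the lower number of compound 2 is not kept through this change. Compound 4 gives a limit of the assay and not a number, and with compound 1 also at a limit, both chlorophenyl amides shown end there, while the 4-bromophenyl amide, compound 2, gives a number: the limit of > 128000 nM in this assay, at which 2 of the 4 values shown sit. The step between compound 1 and compound 4 cannot be read, as both values are limits, so these results do not tell whether moving the chlorine from one ring place to the other changes anything.

The change from compound 2 to compound 4 alters the halogen and its place on the ring together, and a 3-bromophenyl group on the same amide-type nitrogen would be the one-change link that separates these two parts. Also open, from the compounds shown here alone, is how the cells would respond to a phenyl ring carrying an amine or a carboxylic acid instead of a halogen, with the rest of the shared core kept the same.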